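Swapping hydroxy for amino: a half-life estimate for compound 3

This account rests on a few compounds, and the source may have more. Where it says the series, first, only, none or still open, it means among the compounds named here.

Compound 1 `CC(=O)c1cc(C(=O)O)c(Nc2ccc(I)cc2F)n1C`: 0.117 h
Compound 2 `CC(=O)c1cc(C(=O)N2CC(O)C2)c(Nc2ccc(I)cc2F)n1C`: 0.217 h

For the measured compounds named here, in an in vitro ADME assay on microsomes from liver (Rattus norvegicus) for metabolic stability (a higher number here means that the compound lasts longer, a lower number that the compound disappears faster), compound 2 gives 0.217 h, which lies within the scatter of compound 1, the only other compound measured. Compound 3 `CC(=O)c1cc(C(=O)N2CC(N)C2)c(Nc2ccc(I)cc2F)n1C` differs from compound 2 as follows: amino in place of hydroxy on a saturated ring carbon. In words, it carries amino in place of hydroxy on a saturated ring carbon, so 3-aminoazetidin-1-yl replaces 3-hydroxyazetidin-1-yl. Going by the values given here, the only measured step that bears on this is a 1.9-fold higher number from compound 1 to compound 2 (0.27 log units; within the scatter). That step introduced 3-hydroxyazetidin-1-yl in place of hydroxy on a carbonyl carbon, and it does not test the amino group. With no measured step beyond the scatter to guide it, the expectation in this assay is for no change beyond the scatter, in either direction. The expected step is a 1.1-fold lower number from compound 2 to compound 3 (0.04 log units; within the scatter). For compound 3 the estimated half-life is 0.2 h, with an expected range of 0.1 h to 0.4 h.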

Compound 3, half-life: 1.07 h
Compound 3: the middle estimate sits 5.4-fold (0.73 log units) below what was measured; the measured number lies above the stated range.
By their numbers in this assay, from the lowest: compounds 1 and 2 (each within the scatter of the next); then compound 3.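

In this assay, for the compounds shown here, the exchange on this saturated ring carbon, two ring bonds from the ring nitrogen, gives the first step beyond the scatter (a 4.9-fold higher number from compound 2 to compound 3 (0.69 log units; beyond the scatter)), even though hydroxy and amino match in the counts of heavy atoms, hydrogen-bond donors and acceptors and in net charge. Set against hydroxy on a carbonyl carbon, 3-aminoazetidin-1-yl also clears the scatter (a 9.1-fold higher number from compound 1 to compound 3 (0.96 log units; beyond the scatter)), which 3-hydroxyazetidin-1-yl did not. No measurement at hand accounts for this result.

From the compounds shown here alone, it remains open whether a methylamino or dimethylamino group, or an aminomethyl chain, on the same ring carbon would keep, extend or lose this step. Going by these compounds, it is equally open whether the amino group would give a similar step on any core other than the shared one.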